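Swapping an Ester for a Substituted Benzyl Ether

The source may report more compounds than this note shows. Statements on the series, on what has been measured and on what is new or still open speak of the compounds shown alone.

In a functional assay on HepG2 cells (Homo sapiens) for antiproliferative activity, read by MTT assay, with a stated time of 24 h (on this read-out higher numbers stand for weaker inhibition and lower numbers for stronger inhibition), compound 1 `C#CCOc1ccc2c(=O)c(-c3cc(OC)c(OC)cc3OC)coc2c1` gives 4950 nM and compound 2 `COc1cc(OC)c(-c2coc3cc(OCc4ccccc4)ccc3c2=O)cc1OC` gives 1320 nM. Replacing ethynyl with phenyl on that chain produces a 3.8-fold lower number from compound 1 to compound 2 (0.57 log units; beyond the scatter).

Compound 3 `COc1cccc(C(=O)Oc2ccc3c(=O)c(-c4cc(OC)c(OC)cc4OC)coc3c2)c1` reports only a limit of the assay, > 10000 nM. Its place on the scale is the limit of > 10000 nM in this assay, at which 1 of the 3 values shown sits.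

Compound 4 `COc1cc(OC)c(-c2coc3cc(OCc4ccccc4C(F)(F)F)ccc3c2=O)cc1OC` carries 2-(trifluoromethyl)benzyl in place of (3-methoxyphenyl)carbonyl on an oxygen on an aromatic ring. The most relevant measured step is an at least 7.5-fold higher number from compound 2 to compound 3 (0.87 log units; beyond the scatter), which replaces benzyl with that same carbonyl group. The other step into compound 3, an at least 2.0-fold higher number from compound 1 to compound 3 (0.30 log units; that floor lies within the scatter), adds little, as its floor lies within the scatter. Read backwards, the step from compound 2 suggests that restoring a benzyl group should lower the number, though no trifluoromethyl compound has yet been measured. In this assay, the expected change is an at least 5.0-fold lower number from compound 3 to compound 4 (0.69 log units; beyond the scatter), a step beyond the scatter. The estimate for compound 4 is 2000 nM, with an expected range from 600 nM to 7000 nM.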

Compound 4, half-maximal inhibitory concentration: 6550 nM
Compound 4: the middle estimate sits 3.3-fold (0.52 log units) below what was measured; the range from low to high includes it.
By their numbers in this assay, from the lowest: compound 2; then compounds 1 and 4 (each within the scatter of the next). At a limit, above all of these: compound 3.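

Trifluoromethyl in place of hydrogen on an aromatic carbon of the benzyl group gives a 5.0-fold higher number from compound 2 to compound 4 (0.70 log units; beyond the scatter), the first sign that this benzyl ether does not accept every addition. Against the propargyl ether, the change gives a 1.3-fold higher number from compound 1 to compound 4 (0.12 log units; within the scatter), and on this read-out the 2-(trifluoromethyl)benzyl and propargyl groups cannot be told apart. The step away from the ester, an at least 1.5-fold lower number from compound 3 to compound 4 (0.18 log units; that floor lies within the scatter), gives only a floor and cannot size the gain from ester to ether, because compound 3 stands at a limit: the limit of > 10000 nM in this assay, at which 1 of the 4 values shown sits.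

Only one substituent on the benzyl group appears here. Going by these compounds, whether a methyl, a chlorine or an amine on that aromatic carbon would shift the number in the same way remains open.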